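The source may report more compounds than this note shows. Statements on the series, on what has been measured and on what is new or still open speak of the compounds shown alone.

Compound 3 `Oc1cncc(N2CCCNCC2)c1` stands highest of the three measured compounds in an assay on HEK293 cells with Neuronal acetylcholine receptor; alpha4/beta2 (Homo sapiens) as the target, read by FLIPR and calcium flux (a higher number here means a larger maximal response, a lower number a smaller maximal response), where compound 3 gives 120%. Compound 2 `NC(=O)c1cncc(N2CCCNCC2)c1` gives 56%, and compound 1 `C/C=C\Oc1cncc(N2CCCNCC2)c1` gives 45%; both steps of a number 64 percentage points higher from compound 2 to compound 3 (beyond the scatter) and a number 75 percentage points higher from compound 1 to compound 3 (beyond the scatter) lie beyond the scatter. Compound 4 `C=COc1cncc(N2CCCNCC2)c1` carries the change (vinyl in place of hydrogen on an oxygen on an aromatic ring). The step that bears on it is a number 75 percentage points higher from compound 1 to compound 3 (beyond the scatter), which runs in the opposite direction: hydrogen in place of prop-1-en-1-yl on the oxygen raised the maximal response by a large margin. Vinyl entering the same oxygen is therefore expected to lower the maximal response, with the expected step for compound 4 being a number 65 percentage points lower from compound 3 to compound 4 (beyond the scatter), a large drop. Compound 4 is estimated at 55%, with a range from 35% to 80%.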

Compound 4, largest response reached (reported as efficacy), in percent of the reference or control that the assay uses: 61%
For compound 4 the middle estimate is 6 percentage points below the measured one; the range from low to high includes it.
By their numbers in this assay, from the lowest: compound 1; then compounds 2 and 4 (each within the scatter of the next); then compound 3.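

In this assay, a small vinyl group on the oxygen on the aromatic ring already removes much of the maximal response of the free hydroxy (a number 59 percentage points lower from compound 3 to compound 4 (beyond the scatter)). The size of the group on that oxygen still matters, as vinyl in place of prop-1-en-1-yl recovers part of the response (a number 16 percentage points higher from compound 1 to compound 4 (beyond the scatter)), while vinyloxy and carbamoyl on the aromatic carbon cannot be told apart (a number 5 percentage points higher from compound 2 to compound 4 (within the scatter)). Nothing at hand accounts for these steps.

Open questions are what a methyl or ethyl group on the same oxygen would give, and whether an amine in place of the hydroxy would keep the high response of compound 3.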